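A Phenyl for a Methyl on the Piperazine Nitrogen

This account rests on a few compounds, and the source may have more. Where it says the series, first, only, none or still open, it means among the compounds named here.

Measured so far in a functional assay on HT-29 cells (Homo sapiens) for cytotoxicity, read by MTT assay, with a stated time of 24 h, tested at 6.4 ug/mL; a higher number here means a stronger effect of the compound at the concentration tested, a lower number a weaker effect:
compound 1, `Cn1c(-c2ccc(NC(=O)CSc3nc4cc(Cl)ccc4o3)cc2)nc(-c2ccccc2)c1-c1ccccc1`, gives 29.4%
compound 2, `Cn1nnnc1SCC(=O)Nc1ccc(-c2nc(-c3ccccc3)c(-c3ccccc3)n2C)cc1`, gives 60.6%
compound 3, `CN1CCN(CC(=O)Nc2ccc(-c3nc(-c4ccccc4)c(-c4ccccc4)n3C)cc2)CC1`, gives 28.8%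

Compound 3 stands lowest of the three in this assay. Its nearest neighbour is compound 1, a step of a number 0.6 percentage points lower from compound 1 to compound 3 (within the scatter); its furthest is compound 2, a step of a number 31.8 percentage points lower from compound 2 to compound 3 (beyond the scatter). Compound 4, `Cn1c(-c2ccc(NC(=O)CN3CCN(c4ccccc4)CC3)cc2)nc(-c2ccccc2)c1-c1ccccc1`, differs from compound 3 by phenyl in place of methyl on an amine nitrogen in a ring. For the measured compounds named here, no measured step alters the group on that ring nitrogen; the two steps that touch this region of the molecule exchange the whole side group, and they were of very different size, so they set no direction for the present change. Compound 4 is therefore expected near compound 3, at 33% with a range of 15% to 58%, an expected step of a number 4.2 percentage points higher from compound 3 to compound 4 (within the scatter) within the scatter.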

Compound 4, a percentage reported as activity, at one concentration (the size of the read-out at that concentration, not a potency): 46.5%
Compound 4: the middle estimate sits 13.5 percentage points below what was measured; the measured number falls inside the stated range.
By their numbers in this assay, from the lowest: compounds 3 and 1 (each within the scatter of the next); then compound 4; then compound 2.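

In this assay the group on the ring nitrogen proves to count, since phenyl in place of methyl moves the number beyond the scatter (a number 17.7 percentage points higher from compound 3 to compound 4 (beyond the scatter)). The 4-phenylpiperazin-1-yl side group thereby separates from the (5-chloro-1,3-benzoxazol-2-yl)sulfanyl group (a number 17.1 percentage points higher from compound 1 to compound 4 (beyond the scatter)), yet it stays short of the (1-methyl-1H-tetrazol-5-yl)sulfanyl group (a number 14.1 percentage points lower from compound 2 to compound 4 (beyond the scatter)). Nothing at hand explains this gain. Going by these compounds, whether an ethyl or a benzyl group on that nitrogen would move the number the same way remains open. So does the effect of a chlorine or a methoxy group on the new phenyl ring.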